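A Methoxy Group Joins the Anilino Ring

The compounds below may be only part of what the source reports. "The series", "measured", "known", "first", "only" and "open" are said of these compounds alone.

Of the compounds shown here, two that share one core have been measured in a functional assay on B16-F10 cells (Mus musculus) for inhibition, read by MTT assay, with a stated time of 72 h; a lower number here means a stronger inhibitor, a higher number a weaker inhibitor. Compound 1 `CC(C)c1ccc(-c2nc(SCc3cn(CC(=O)NC(=O)Nc4ccccn4)nn3)nc(Nc3ccc(F)cc3)c2C#N)cc1` carries a fluoro group on its anilino ring, and in this assay compound 1 gives 7250 nM. Compound 2 `CC(C)c1ccc(-c2nc(SCc3cn(CC(=O)NC(=O)Nc4ccccn4)nn3)nc(Nc3ccccc3)c2C#N)cc1` has a hydrogen in that place, and in this assay compound 2 gives 14300 nM. The step between them is a 2.0-fold higher number from compound 1 to compound 2 (0.29 log units; within the scatter), so the two numbers cannot be told apart. Compound 2 stands beside compound 1 with a gap that lies within the scatter, and neither can be called the stronger or the weaker.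

Compound 3 `COc1ccc(Nc2nc(SCc3cn(CC(=O)NC(=O)Nc4ccccn4)nn3)nc(-c3ccc(C(C)C)cc3)c2C#N)cc1` differs from compound 2 by methoxy in place of hydrogen on an aromatic carbon. Among the measured compounds shown here, the one measured step that touches the same place on the anilino ring, a 2.0-fold higher number from compound 1 to compound 2 (0.29 log units; within the scatter), stayed within the scatter, so the numbers give no sign that a change at this place moves the result. Compound 3 is expected to show a 1.3-fold lower number from compound 2 to compound 3 (0.11 log units; within the scatter), which means no change beyond the scatter. The estimate for compound 3 in this assay is 11000 nM, with a range from 4000 nM to 30000 nM.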

Compound 3, half-maximal inhibitory concentration: 360 nM
Compound 3: the middle estimate sits 31-fold (1.49 log units) above what was measured, outside the stated range (below it).
By their numbers in this assay, from the lowest: compound 3; then compounds 1 and 2 (each within the scatter of the next).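

The place on the anilino ring para to a large group looked unresponsive while only fluoro and hydrogen were exchanged there, but in this assay it proves highly sensitive to what it carries. Methoxy in place of hydrogen gives a 40-fold lower number from compound 2 to compound 3 (1.60 log units; beyond the scatter) and methoxy in place of fluoro gives a 20-fold lower number from compound 1 to compound 3 (1.30 log units; beyond the scatter) in the same assay, both beyond the scatter, which makes compound 3 the strongest inhibitor of the three and shows that the earlier flat step did not speak for every group at this carbon. Nothing available explains why methoxy has so large an effect here.

From the compounds shown here alone, it remains open which part of methoxy carries the gain, and a hydroxy group, a methyl group or the longer ethoxy chain on this same carbon would help to separate the oxygen from the carbon attached to it. Going by these compounds, it is also open whether methoxy would have a step of similar size if the 4-isopropylphenyl group or the chain ending in the pyridine-bearing urea were replaced by a different group.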